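A few compounds are considered here, and "the series" means these few. Any claim that something is new, unique, unknown or untested is made for them only; others in the source may bear on it.

Measured so far:
compound 1 `CC(=O)c1cc(-c2ccc(S(N)(=O)=O)cc2)n(-c2ccc(Cl)cc2)n1` — 86800 nM
compound 2 `CCC(=O)c1cc(-c2ccc(S(N)(=O)=O)cc2)n(-c2cccc(Cl)c2)n1` — 6900 nM

In a physicochemical assay for solubility, read by HPLC, in phosphate buffer, measured as kinetic solubility, at pH 7.4 (a higher number here means a more soluble compound, a lower number a less soluble compound), compound 1 holds the higher of the two numbers; compound 2 sits well below it, beyond the scatter. Compound 3 `NS(=O)(=O)c1ccc(-c2cc(C(=O)NC3CC3)nn2-c2ccc(Cl)cc2)cc1` has not been measured. It differs from compound 1 in one place:

cyclopropylamino in place of methyl on a carbonyl carbon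

Within the data shown here, no measured pair shows this change, so the direction rests on the change alone. A modest downward step is expected, a 1.7-fold lower number from compound 1 to compound 3 (0.24 log units; within the scatter), as the solubility of compound 3 is estimated from compound 1 at 86800 nM. Compound 3 is thus expected to give about 50000 nM, within a range of 15000 nM to 150000 nM.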

Compound 3, solubility: 72600 nM
For compound 3 the middle estimate is 1.5-fold (0.16 log units) below the measured one, within the range that was stated.
By their numbers in this assay, from the lowest: compound 2; then compounds 3 and 1 (each within the scatter of the next).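

In this assay cyclopropylamino in place of methyl on a carbonyl carbon gives a 1.2-fold lower number from compound 1 to compound 3 (0.08 log units; within the scatter) and so this position takes a three-membered ring and a hydrogen-bond donor with no step beyond the scatter. Among these compounds, compound 2 differs from compound 1 in more than one place, so only this pair reads the change on its own. No measurement shown here accounts for this result. On these data alone, whether a carboxylic acid or a primary amide on this carbonyl carbon would stay as close to compound 1 remains open. So does the outcome for a longer chain on the amide nitrogen in place of the cyclopropyl ring.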